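The source may report more compounds than this note shows. Statements on the series, on what has been measured and on what is new or still open speak of the compounds shown alone.

Of the compounds shown here, three built on one shared core have been measured in a functional assay on the whole organism with Rattus norvegicus as the target, at a dose of 20 mg/kg by the intraperitoneal route; a higher number here means more inhibition at the dose given (going by the name of the read-out), a lower number less inhibition. Compound 1 `CS(=O)(=O)c1cccc(-c2nc(N)nc(N)n2)c1` gives -6%. Compound 2 `Nc1nc(N)nc(-c2cccc(Br)c2)n1` gives 96%. Compound 3 `CSc1cccc(-c2nc(N)nc(N)n2)c1` gives 49%, the second highest of the three numbers, since the read-out is a number 47 percentage points lower from compound 2 to compound 3 (beyond the scatter) and a number 55 percentage points higher from compound 1 to compound 3 (beyond the scatter). Compound 4 `Nc1nc(N)nc(-c2cccc(SC(F)(F)F)c2)n1` differs from compound 3 by trifluoromethyl in place of methyl on a sulfur. Going by the values given here, no measured step changes the group sitting on the sulfur, so nothing bears directly on this change; those two steps only show that the group at this position can swing the read-out widely. On that basis only a moderate rise is expected, a number 16 percentage points higher from compound 3 to compound 4 (beyond the scatter). Compound 4 is therefore estimated at 65%, with a wide range from 25% to 95%.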

Compound 4, a percentage reported as inhibition, in the whole organism at one dose (the size of the read-out at that dose, not a potency) in the Rattus norvegicus assay: 87%
For compound 4 the middle estimate is 22 percentage points below the measured one; low and high end bracket the measured number.
By their numbers in the Rattus norvegicus assay, from the lowest: compound 1; then compound 3; then compounds 4 and 2 (each within the scatter of the next).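

Going by these compounds alone, in the Rattus norvegicus assay, changing only the group on the sulfur gives a number 38 percentage points higher from compound 3 to compound 4 (beyond the scatter), so this position responds strongly to a change that no earlier step tested. Replacing the whole substituent gives a number 93 percentage points higher from compound 1 to compound 4 (beyond the scatter), while the comparison with bromo gives a number 9 percentage points lower from compound 2 to compound 4 (within the scatter). In a physicochemical assay for lipophilicity (a lower number here means a more polar compound, a higher number a more lipophilic compound), compound 3 gives 2.16 and compound 4 gives 3.2, so the same change also shifts this second read-out.

With one pair shown in both assays, whether the two read-outs track each other stays open. Also open, going by these compounds, is how a longer chain on the sulfur, or a carboxylic acid on the aromatic carbon, would read in the Rattus norvegicus assay.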